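The source may hold more compounds than are shown below. What is called first, only, known or untested is meant among the compounds shown, and "the series" means these compounds.

In an assay on membranes from Sf9 cells for displacement of a labelled ligand from histamine H2 receptor (Homo sapiens), read by scintillation counting, with a stated time of 60 min (on this read-out higher numbers stand for weaker inhibition and lower numbers for stronger inhibition), three compounds that share one core have been measured. Compound 1 `Cc1nc(N)sc1CCCN/C(N)=N/C(=O)NC1CCCCC1` gives 170 nM. Compound 2 `CCCCCNC(=O)/N=C(\N)NCCCc1sc(N)nc1C` gives 4.47 nM. Compound 3 `Cc1nc(N)sc1CCCN/C(N)=N/C(=O)N[C@@H](C)c1ccccc1` gives 51.3 nM, the second highest of the three numbers; its nearest neighbour is reached by a 3.3-fold lower number from compound 1 to compound 3 (0.52 log units; beyond the scatter), and its furthest by an 11-fold higher number from compound 2 to compound 3 (1.06 log units; beyond the scatter).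

Compound 4 `CCCCCCNC(=O)/N=C(\N)NCCCc1sc(N)nc1C` has not yet been measured. It differs from compound 3 in one place: hexyl in place of 1-phenylethyl on an amide-type nitrogen. Among the measured compounds shown here, two measured steps bear on this change. The first is an 11-fold higher number from compound 2 to compound 3 (1.06 log units; beyond the scatter), which shows that exchanging a straight chain for the 1-phenylethyl group on the amide-type nitrogen raised the number well beyond the scatter; compound 4 goes the other way, back to a straight chain. The second is a 38-fold lower number from compound 1 to compound 2 (1.58 log units; beyond the scatter), which shows the pentyl chain on that nitrogen far below the cyclohexyl ring. Hexyl is a chain of the same kind as pentyl, one carbon longer, and nothing among the three measured compounds speaks against a chain of this length. Compound 4 is therefore expected to show a large downward step in this assay, a 10-fold lower number from compound 3 to compound 4 (1.01 log units; beyond the scatter). Compound 4 is estimated at 5 nM, most plausibly between 1.5 nM and 16 nM.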

Compound 4, inhibition constant: 28.8 nM
Estimate against measurement, compound 4: 5.8-fold (0.76 log units) below, and the stated range ends below it.
By their numbers in this assay, from the lowest: compound 2; then compounds 4 and 3 (each within the scatter of the next); then compound 1.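

In this assay, hexyl and 1-phenylethyl on the amide-type nitrogen cannot be told apart (a 1.8-fold lower number from compound 3 to compound 4 (0.25 log units; within the scatter)), so among these compounds, an open chain on this nitrogen does not by itself give a number as low as that of compound 2. The low number of compound 2 also does not carry over to a chain one carbon longer (a 6.4-fold higher number from compound 2 to compound 4 (0.81 log units; beyond the scatter)), which shows that a single methyl in place of hydrogen on a saturated chain carbon, five bonds along the chain from the amide-type nitrogen, changes the result beyond the scatter. Hexyl still keeps a clear margin over cyclohexyl, though a smaller one than pentyl showed (a 5.9-fold lower number from compound 1 to compound 4 (0.77 log units; beyond the scatter)), and nothing available explains any of these steps.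

From the compounds shown here alone, with only pentyl and hexyl as open chains, it remains open whether butyl or heptyl would fall closer to compound 2 or to compound 4, and so whether pentyl marks a true optimum in chain length. The compounds shown also leave open how a benzyl group or the opposite stereoisomer of 1-phenylethyl would compare at this nitrogen.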